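A few compounds are considered here, and "the series" means these few. Any claim that something is new, unique, unknown or untested is made for them only; others in the source may bear on it.

In a functional assay, read by spectrophotometry (a higher number here means that more compound is needed for the effect, a lower number that less compound is needed), three compounds with a shared core and chains of different length have been measured. Compound 1 `COc1ccc(-c2cc(=O)c3ccc(OCCCN4CCC(C)CC4)cc3o2)cc1` gives 26.6 nM, compound 2 `COc1ccc(-c2cc(=O)c3ccc(OCCCCN4CCC(C)CC4)cc3o2)cc1` gives 28.1 nM and compound 3 `COc1ccc(-c2cc(=O)c3ccc(OCCCCCN4CCC(C)CC4)cc3o2)cc1` gives 31.7 nM, so compound 3 stands level with the other two. Compound 4 `COc1ccc(-c2cc(=O)c3ccc(OCCCCCN4CCC(CCO)CC4)cc3o2)cc1` keeps the chain of compound 3 but carries hydroxymethyl in place of hydrogen on a saturated chain carbon bound to a saturated ring carbon, turning methyl into 2-hydroxyethyl: hydroxymethyl in place of hydrogen on a saturated chain carbon bound to a saturated ring carbon. The nearest evidence is the chain steps, a 1.1-fold higher number from compound 1 to compound 2 (0.02 log units; within the scatter), a 1.1-fold higher number from compound 2 to compound 3 (0.05 log units; within the scatter) and a 1.2-fold higher number from compound 1 to compound 3 (0.08 log units; within the scatter), all small. None of them alters this group, so they bear on it only indirectly and suggest no direction. The step expected in this assay is a 1.1-fold higher number from compound 3 to compound 4 (0.04 log units; within the scatter), nothing beyond the scatter. For compound 4 the estimate is 35 nM, with a deliberately wide expected range of 13 nM to 95 nM.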

Compound 4, half-maximal effective concentration: 27.9 nM
Compound 4: the middle estimate sits 1.3-fold (0.10 log units) above what was measured; the range from low to high includes it.
By their numbers in this assay, from the lowest: compounds 1, 4, 2 and 3 (each within the scatter of the next).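

In this assay, the result shows that methyl can become 2-hydroxyethyl on this ring with no readable change: the step is a 1.1-fold lower number from compound 3 to compound 4 (0.06 log units; within the scatter). The two steps that also alter the chain length, a 1.0-fold lower number from compound 2 to compound 4 (0.00 log units; within the scatter) and a 1.0-fold higher number from compound 1 to compound 4 (0.02 log units; within the scatter), are equally small. Nothing measured here accounts for this. As far as these compounds go, what remains open is whether an amine or a carboxylic acid in place of the hydroxyl, or a longer chain carrying the hydroxyl, would also leave the number level.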